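The source may hold more compounds than are shown below. What is called first, only, known or untested is meant among the compounds shown, and "the series" means these compounds.

Three compounds share one core and differ only in the chain attached to one aromatic carbon of it. Compound 1 `COc1ccc(C(=O)/C=C/c2cc(-c3cc(OC)c(OC)c(OC)c3)n3nc(-c4ccccc4)cc3n2)cc1` gives 79800 nM in an ADME assay on HEK293 cells (Homo sapiens) for antiproliferative activity, read by MTT assay, with a stated time of 24 h; on this read-out higher numbers stand for weaker inhibition and lower numbers for stronger inhibition. Compound 2 `COc1cc(-c2cc(C(=O)/C=C/c3ccc(Cl)cc3)nc3cc(-c4ccccc4)nn23)cc(OC)c1OC` gives 53900 nM in this assay, and compound 3 `COc1cc(-c2cc(/C=C/C(=O)c3ccc(C)c(C)c3)nc3cc(-c4ccccc4)nn23)cc(OC)c1OC` gives 72500 nM in this assay. The number for compound 3 is the second highest of the three, but the gaps to both neighbours are within the scatter: a 1.1-fold lower number from compound 1 to compound 3 (0.04 log units; within the scatter) and a 1.3-fold higher number from compound 2 to compound 3 (0.13 log units; within the scatter). Compound 4 `COc1ccc(/C=C/C(=O)c2cc(-c3cc(OC)c(OC)c(OC)c3)n3nc(-c4ccccc4)cc3n2)cc1` has not yet been measured. It differs from compound 3 in one place: (2-(4-methoxyphenyl)ethenyl)carbonyl in place of 2-((3,4-dimethylphenyl)carbonyl)ethenyl on an aromatic carbon. Among the measured compounds shown here, two measured steps bear on this. Putting a 4-methoxyphenyl where a 3,4-dimethylphenyl sat on the carbonyl carbon gave a 1.1-fold lower number from compound 1 to compound 3 (0.04 log units; within the scatter). Reversing the order of carbonyl and ethenyl in the chain gave a 1.3-fold higher number from compound 2 to compound 3 (0.13 log units; within the scatter). Since neither left the scatter, no step beyond the scatter is expected in this assay, so the expected step is a 1.1-fold lower number from compound 3 to compound 4 (0.05 log units; within the scatter). Compound 4 is therefore estimated at 65000 nM, with a range from 35000 nM to 130000 nM.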

Compound 4, half-maximal inhibitory concentration: 46600 nM
For compound 4 the middle estimate is 1.4-fold (0.14 log units) above the measured one, and the stated range covers the measured number.
By their numbers in this assay, from the lowest: compounds 4, 2, 3 and 1 (each within the scatter of the next).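

In this assay, among the compounds shown here, reversing the order of carbonyl and ethenyl with the 4-methoxyphenyl kept in place, a change no earlier pair isolated, gives a 1.7-fold lower number from compound 1 to compound 4 (0.23 log units; within the scatter) and so shows that chain order alone produces no step beyond the scatter here. With the chain order held, methoxy in place of chloro gives a 1.2-fold lower number from compound 2 to compound 4 (0.06 log units; within the scatter) for the first clean test of that ring group on this chain, and changing chain order and ring groups together gives a 1.6-fold lower number from compound 3 to compound 4 (0.19 log units; within the scatter) without leaving the scatter either. Among these four compounds, this position therefore tolerates all of these changes with no step beyond the scatter.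

Nothing available here offers an explanation for these numbers.
Every chain shown ends in a phenyl ring carrying methoxy, chloro or methyl groups, so it remains open whether an amine or a carboxylic acid on that ring, or a longer chain at this position, would move the number beyond the scatter.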